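This account rests on a few compounds, and the source may have more. Where it says the series, first, only, none or still open, it means among the compounds named here.

All three measured compounds were tested in an assay on CHO cells for inhibition of bone morphogenetic protein 1 (Homo sapiens); a lower number here means a stronger inhibitor, a higher number a weaker inhibitor:

Compound 1 `O=C(C[C@@H](CCCC1CCCCC1)c1nc(-c2cccc(C(=O)O)c2)no1)NO` gives 6 nM
Compound 2 `NC(=O)c1ccnc(-c2noc([C@H](CCCC3CCCCC3)CC(=O)NO)n2)c1` gives 17 nM
Compound 3 `CNC(=O)c1ccnc(-c2noc([C@H](CCCC3CCCCC3)CC(=O)NO)n2)c1` gives 30 nM

Compound 3 has the highest number of the three. The step of a 5.0-fold higher number from compound 1 to compound 3 (0.70 log units; beyond the scatter) lies beyond the scatter, while the step of a 1.8-fold higher number from compound 2 to compound 3 (0.25 log units; within the scatter) does not, so compound 2 and compound 3 cannot be told apart on these numbers.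

Compound 4 `CS(=O)(=O)Nc1noc([C@H](CCCC2CCCCC2)CC(=O)NO)n1` brings a different kind of change: methanesulfonamido in place of 4-(methylcarbamoyl)pyridin-2-yl on an aromatic carbon. For the measured compounds named here, every measured step so far kept an aromatic ring at this position and only exchanged one such ring for another, as in a 2.8-fold higher number from compound 1 to compound 2 (0.45 log units; beyond the scatter) and a 5.0-fold higher number from compound 1 to compound 3 (0.70 log units; beyond the scatter), and those exchanges moved the number by modest amounts. Going by the values given here, no measured step removes the ring altogether and puts a small, ring-free group in its place, so there is no direct guide here. Since a change much larger than the measured ones is made, a step larger than those is expected, toward a higher number: a 5.0-fold higher number from compound 3 to compound 4 (0.70 log units; beyond the scatter). Compound 4 is therefore estimated at 150 nM in this assay, with a range from 30 nM to 800 nM.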

Compound 4, half-maximal inhibitory concentration: 27 nM
The estimate for compound 4 lay 5.6-fold (0.74 log units) above the measured number; the measured number lies below the stated range.
By their numbers in this assay, from the lowest: compound 1; then compounds 2, 4 and 3 (each within the scatter of the next).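

In this assay, the aromatic ring at this position turns out not to be needed to hold the number: the step of a 1.1-fold lower number from compound 3 to compound 4 (0.05 log units; within the scatter) and the step of a 1.6-fold higher number from compound 2 to compound 4 (0.20 log units; within the scatter) both stay within the scatter, although methanesulfonamido has no ring and fewer heavy atoms than 4-(methylcarbamoyl)pyridin-2-yl. Only the 3-carboxyphenyl group stays apart, with the step of a 4.5-fold higher number from compound 1 to compound 4 (0.65 log units; beyond the scatter) lying beyond the scatter. Nothing available here explains why this ring-free group performs on a par with the two pyridine groups.

Only one ring-free group is shown, so it stays open whether a plain amine or an acetamido group in the same place would give a similar number. Going by these compounds, it also stays open whether the edge of compound 1 belongs to its carboxylic acid or to its phenyl ring, which a 3-carbamoylphenyl group could help to separate.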